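Ester Chain Length and Cell Toxicity in Three Nucleoside Esters

The source may hold more compounds than are shown below. What is called first, only, known or untested is meant among the compounds shown, and "the series" means these compounds.

Measured compounds in a functional assay on HeLa cells (Homo sapiens) for cytotoxicity, read by cell counting, with a stated time of 48 h; on this read-out lower numbers stand for an effect already at smaller amounts and higher numbers for an effect only at larger amounts of compound:
compound 1, `CCCCCCCCCCCCCCCC(=O)O[C@H]1[C@H](O)[C@H](n2ccc(N)nc2=O)O[C@@H]1CO`, gives 0.24 ug/mL
compound 2, `CCCCCCCCCCCCCC(=O)O[C@H]1[C@H](O)[C@H](n2ccc(N)nc2=O)O[C@@H]1CO`, gives 0.08 ug/mL
compound 3, `CC(=O)O[C@H]1[C@H](O)[C@H](n2ccc(N)nc2=O)O[C@@H]1CO`, gives 0.14 ug/mL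

Compound 3, the shortest ester of the three, sits within the scatter of both compound 1 and compound 2, so the three numbers cannot be ordered with confidence. Within the data shown here, the only change that reaches beyond the scatter is a 3.0-fold lower number from compound 1 to compound 2 (0.48 log units; beyond the scatter), where two carbons leave the end of a long chain. Among the measured compounds shown here, compound 4, `CCCCCCCC(=O)O[C@H]1[C@H](O)[C@H](n2ccc(N)nc2=O)O[C@@H]1CO`, arises from compound 3 by hexyl in place of hydrogen on a saturated chain carbon bound to a carbonyl carbon, a far larger growth of the chain, but at a place no measured step covers. Since every measured value lies close together, a step of a 1.2-fold lower number from compound 3 to compound 4 (0.07 log units; within the scatter) is expected, with compound 4 estimated at 0.12 ug/mL, between 0.04 ug/mL and 0.35 ug/mL.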

Compound 4, concentration for half-maximal effect: 0.1 ug/mL
The estimate for compound 4 lay 1.2-fold (0.08 log units) above the measured number, within the range that was stated.
By their numbers in this assay, from the lowest: compounds 2, 4, 3 and 1 (each within the scatter of the next, the first and the last beyond it).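

Hexyl in place of hydrogen on a saturated chain carbon bound to a carbonyl carbon gives a 1.4-fold lower number from compound 3 to compound 4 (0.15 log units; within the scatter) in this assay, so even this large growth of the chain leaves no clear difference. Along the long chains, the shorter one gives a 1.3-fold higher number from compound 2 to compound 4 (0.10 log units; within the scatter) and the longer one gives a 2.4-fold lower number from compound 1 to compound 4 (0.38 log units; beyond the scatter), the only new step that clears the scatter. The data shown offer no explanation for these numbers.

Whether a chain ending in an amine or a carboxylic acid would fit among these plain chains stays open.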